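The compounds below may be only part of what the source reports. "The series", "measured", "known", "first", "only" and "open" are said of these compounds alone.

In a functional assay on NT2 cells (Homo sapiens) for inhibition (on this read-out higher numbers stand for weaker inhibition and lower numbers for stronger inhibition), compound 3 `CCC(C(=O)N[C@@H](CC(=O)O)C(=O)CSCc1ccccc1)n1ccnc(NCCCOC)c1=O` gives > 10 nM, which is a limit of the assay and not a number. Compound 1 `CCC(C(=O)N[C@@H](CC(=O)O)C(=O)CSCc1ccccc1)n1ccnc(NCc2cccs2)c1=O` gives 4.56 nM and compound 2 `CCC(C(=O)N[C@@H](CC(=O)O)C(=O)CSCc1ccccc1)n1ccnc(NCc2cc(C)no2)c1=O` gives 6.41 nM, and these two are joined by a 1.4-fold higher number from compound 1 to compound 2 (0.15 log units; within the scatter).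

Compound 4 `CCC(C(=O)N[C@@H](CC(=O)O)C(=O)CSCc1ccccc1)n1ccnc(NCc2nc(C)no2)c1=O` differs from compound 3 as follows: 3-methyl-1,2,4-oxadiazol-5-yl in place of 2-methoxyethyl on a saturated chain carbon bound to a nitrogen on an aromatic ring. In words, 3-methyl-1,2,4-oxadiazol-5-yl stands in place of 2-methoxyethyl on a saturated chain carbon bound to a nitrogen on an aromatic ring.

Two measured steps made the reverse kind of exchange, from a five-membered aromatic ring to 2-methoxyethyl. They are an at least 2.1-fold higher number from compound 1 to compound 3 (0.34 log units; beyond the scatter) and an at least 1.5-fold higher number from compound 2 to compound 3 (0.19 log units; that floor lies within the scatter), and the floor of the second lies within the scatter. Compound 2, at 6.41 nM, is the nearest guide, as its ring also carries a methyl group. A modest move to a lower number is therefore expected in this assay. The expected size is an at least 1.4-fold lower number from compound 3 to compound 4 (0.15 log units; that floor lies within the scatter). For compound 4 the estimate is 7 nM, with an expected range from 3.5 nM to 15 nM.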

Compound 4, half-maximal inhibitory concentration: 5.33 nM
Estimate against measurement, compound 4: 1.3-fold (0.12 log units) above; the range from low to high includes it.
By their numbers in this assay, from the lowest: compounds 1, 4 and 2 (each within the scatter of the next). At a limit, above all of these: compound 3.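

In this assay the 3-methyl-1,2,4-oxadiazol-5-yl group joins the two rings already held on a saturated chain carbon bound to a nitrogen on an aromatic ring, with a 1.2-fold lower number from compound 2 to compound 4 (0.08 log units; within the scatter) and a 1.2-fold higher number from compound 1 to compound 4 (0.07 log units; within the scatter), so three five-membered aromatic rings with different hetero atoms cannot be told apart here. Exchanging 2-methoxyethyl for this ring gives an at least 1.8-fold lower number from compound 3 to compound 4 (0.27 log units; that floor lies within the scatter), so even this floor does not establish a real gain. Compound 3 stands at a limit and not at a number, so this step can be read only as a floor: the limit of > 10 nM in this assay, at which 1 of the 4 values shown sits.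

On these data alone, what remains open is how far compound 3 truly lies from the ring-bearing compounds. As far as these compounds go, it is also open whether a phenyl or pyridine ring, or a chain ending in an amine or a carboxylic acid, would be tolerated at this place.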